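The source may hold more compounds than are shown below. What is called first, only, known or untested is meant among the compounds shown, and "the series" means these compounds.

Compound 1, of structure `N#CCCCc1c[nH]c2ccc(F)cc12`, is one of two compounds examined here in an assay on isolated protein for inhibition of Myeloperoxidase (Homo sapiens), read by ELISA, with a stated time of 5 min (a higher number here means a weaker inhibitor, a lower number a stronger inhibitor), where compound 1 gives 72 nM. The second measured compound, compound 2, of structure `NCCCCc1c[nH]c2c(F)cccc12`, differs from compound 1 in more than one place, and in this assay compound 2 gives 21 nM. For the measured compounds named here, of the two numbers, the one for compound 1 stands higher, and the gap between them lies beyond the scatter of repeated measurements.

Compound 3, of structure `CNC(=O)CCCc1c[nH]c2ccc(F)cc12`, keeps the core of compound 1 and alters only the end of the saturated chain: methylcarbamoyl in place of cyano on a saturated chain carbon, three bonds along the chain from an aromatic carbon. No single-change step between measured compounds is available to guide this step, so the expectation rests on the two numbers shown. The change from compound 1 to compound 3 is expected to shift the number only modestly, roughly within or just beyond the scatter, with no strong lean in either direction, as a 1.8-fold higher number from compound 1 to compound 3 (0.26 log units; within the scatter). On that basis compound 3 is estimated to give 130 nM in this assay, with a range from 35 nM to 500 nM.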

Compound 3, half-maximal inhibitory concentration: 95 nM
Beside the measured number, compound 3's estimate is 1.4-fold (0.14 log units) above it, and the stated range covers the measured number.
By their numbers in this assay, from the lowest: compound 2; then compounds 1 and 3 (each within the scatter of the next).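

In this assay, the step reads a 1.3-fold higher number from compound 1 to compound 3 (0.12 log units; within the scatter), so the two compounds cannot be told apart when methylcarbamoyl stands in place of cyano on a saturated chain carbon, three bonds along the chain from an aromatic carbon. The earlier compounds shown here offered no single-change step, whereas this one shows that, on the core of compound 1, this position accepts a group of 4 heavy atoms with 1 hydrogen-bond donor in place of one of 2 heavy atoms with no donor, without a change beyond the scatter. No supporting data bear on why the number holds across this exchange.

The compounds shown leave open whether the same position would accept a carboxylic acid, a dimethylcarbamoyl group or a longer chain ending in methylcarbamoyl with equally little effect on the number. They also leave open whether this result would hold on another core, for the single step shown comes from one pair of compounds that share the same fluorinated core and the same chain length.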